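Coumarin-linked lipoyl amides: aryl change on the core

This account rests on a few compounds, and the source may have more. Where it says the series, first, only, none or still open, it means among the compounds named here.

Measured compounds:
- compound 1 `CC(=O)c1cc2ccc(OCCCn3cc(CNC(=O)CCCCC4CCSS4)nn3)cc2oc1=O` gives 35.5% in a functional assay on PC-12 cells (Rattus norvegicus) for cytotoxicity, read by MTT assay, with stated times of 3 h and 2 h, tested at 1 uM; a higher number here means a stronger effect of the compound at the concentration tested, a lower number a weaker effect
- compound 2 `O=C(CCCCC1CCSS1)NCc1cn(CCCOc2ccc3cc(-c4ccc(Cl)cc4)c(=O)oc3c2)nn1` gives 49.3% in this assay
- compound 3 `COc1ccc(-c2cc3ccc(OCCCCn4cc(CNC(=O)CCCCC5CCSS5)nn4)cc3oc2=O)cc1` gives 36.8% in this assay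

Compound 3 stands second highest of the three numbers in this assay. Its nearest neighbour is compound 1, whose number lies within the scatter of that of compound 3. The furthest is compound 2, whose number lies beyond the scatter above that of compound 3. Compound 2 and compound 3 differ in more than one place, so only their two values can be compared.

Compound 4 `O=C(CCCCC1CCSS1)NCc1cn(CCCCOc2ccc3cc(-c4ccc(Cl)c(Cl)c4)c(=O)oc3c2)nn1` is not yet measured. It differs from compound 3 in one place: 3,4-dichlorophenyl in place of 4-methoxyphenyl on an aromatic carbon

Among the measured compounds shown here, one measured step bears on this: a number 13.8 percentage points higher from compound 1 to compound 2 (beyond the scatter). There a chlorine-bearing phenyl entered at the same place on the core and the number rose modestly. On that basis a modest rise in this assay is expected for compound 4, though the step at hand exchanges one aryl for another rather than replacing an acetyl, so the size is uncertain. The expected step is a number 9.2 percentage points higher from compound 3 to compound 4 (within the scatter). Compound 4 is estimated at 46%, with a range from 34% to 58%.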

Compound 4, a percentage reported as activity, at one concentration (the size of the read-out at that concentration, not a potency): 49.3%
Estimate against measurement, compound 4: 3.3 percentage points below; the measured number falls inside the stated range.
By their numbers in this assay, from the lowest: compounds 1 and 3 (each within the scatter of the next); then compounds 2 and 4 (each within the scatter of the next).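

On this position, one aryl group can replace another and still move the number: in this assay, the change from 4-methoxyphenyl to 3,4-dichlorophenyl gives a number 12.5 percentage points higher from compound 3 to compound 4 (beyond the scatter), so the earlier rise on replacing acetyl is not the only response seen here. Both groups have 8 heavy atoms and one six-membered aromatic ring of carbon only, so this step holds those counts fixed, while the hydrogen-bond acceptor count goes from 1 to 0 and two chlorines enter. Nothing available explains the rise.

On these data alone, compound 2 and compound 4 differ in more than one place, so the separate contribution of the second chlorine remains open. Also open, as far as these compounds go, is what this position would give with a phenyl carrying an amine or a carboxylic acid.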